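Replacing an Aryl Sulfonyl Group with an Aryl Amide

A few compounds are considered here, and "the series" means these few. Any claim that something is new, unique, unknown or untested is made for them only; others in the source may bear on it.

Of the compounds shown here, three built on a shared core have been tested in a functional assay on DU-145 cells (Homo sapiens) for inhibition, read by trypan blue exclusion, with a stated time of 72 h; on this read-out lower numbers stand for stronger inhibition and higher numbers for weaker inhibition. Compound 1 `Cn1c(=O)c(S(=O)(=O)c2ccc(Cl)cc2Cl)cc2cnc(Nc3ccc4[nH]ccc4c3)nc21` gives 1000 nM, compound 2 `Cn1c(=O)c(S(=O)(=O)Cc2ccc(F)cc2)cc2cnc(Nc3ccc4[nH]ccc4c3)nc21` gives 30000 nM, and compound 3 `COc1ccc(S(=O)(=O)c2cc3cnc(Nc4ccc5[nH]ccc5c4)nc3n(C)c2=O)cc1` gives 500 nM. Compound 3 therefore sits level with compound 1, since a 2.0-fold lower number from compound 1 to compound 3 (0.30 log units; within the scatter) stays within the scatter, and well apart from compound 2, as a 60-fold lower number from compound 2 to compound 3 (1.78 log units; beyond the scatter) shows.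

Compound 4 `Cn1c(=O)c(C(=O)Nc2ccc(F)cc2)cc2cnc(Nc3ccc4[nH]ccc4c3)nc21` has not yet been measured. Its structural change from compound 3 is (4-fluorophenyl)carbamoyl in place of (4-methoxyphenyl)sulfonyl on an aromatic carbon, with (4-fluorophenyl)carbamoyl in place of (4-methoxyphenyl)sulfonyl on an aromatic carbon of a six-membered aromatic ring with 1 nitrogen.

Among the compounds with values here, no measured step replaces the sulfonyl group itself, so the evidence is only indirect. Exchanging one directly attached aryl ring for another barely moved the number, with a 2.0-fold lower number from compound 1 to compound 3 (0.30 log units; within the scatter). Compound 2, which carries 4-fluorobenzyl on the sulfonyl sulfur, shows that altering how the ring is attached can matter far more, with a 30-fold higher number from compound 1 to compound 2 (1.48 log units; beyond the scatter). Compound 4 also changes that attachment, but by a different route, so a moderate loss is more likely than a loss of that full size.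

The estimated step in this assay is a 4.0-fold higher number from compound 3 to compound 4 (0.60 log units; beyond the scatter), towards weaker inhibition. Compound 4 is expected at 2000 nM, with an estimated range from 300 nM to 15000 nM.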

Compound 4, half-maximal inhibitory concentration: 5000 nM
Compound 4: middle estimate off by 2.5-fold (0.40 log units), on the low side; measured number inside the range.
By their numbers in this assay, from the lowest: compounds 3 and 1 (each within the scatter of the next); then compound 4; then compound 2.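

Compound 4 is the first of these compounds in which the sulfonyl link itself is replaced, here by a carbamoyl link, and in this assay this weakens inhibition relative to both compounds with an aryl ring directly on the sulfonyl: a 10-fold higher number from compound 3 to compound 4 (1.00 log units; beyond the scatter) and a 5.0-fold higher number from compound 1 to compound 4 (0.70 log units; beyond the scatter). The amide nevertheless does better than the sulfonyl bearing 4-fluorobenzyl, with a 6.0-fold lower number from compound 2 to compound 4 (0.78 log units; beyond the scatter), so this aromatic carbon does not need a sulfonyl group for measurable inhibition, and the group's identity clearly affects the number. Nothing measured alongside these numbers explains these differences.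

The move to compound 4 changes the link and the ring substituent together, from 4-methoxy to 4-fluoro, so these compounds cannot show how much of the loss comes from each change. They also leave open how inhibition would respond to very different groups at this carbon, such as a carboxylic acid, an amine or a longer chain between the amide and the ring.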